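Shifting a Methylindole Attachment Point

The compounds below may be only part of what the source reports. "The series", "measured", "known", "first", "only" and "open" are said of these compounds alone.

- compound 1 `CCOc1cc(-c2ccc3[nH]ccc3c2)cn2c(-c3cc(OC)c(OC)c(OC)c3)nnc12`: 166 nM
- compound 2 `CCOc1cc(-c2ccc3ccn(C)c3c2)cn2c(-c3cc(OC)c(OC)c(OC)c3)nnc12`: 240 nM

Both compounds were tested in a functional assay on HeLa cells (Homo sapiens) for antiproliferative activity, read by MTT assay, with a stated time of 48 h; a lower number here means a stronger inhibitor, a higher number a weaker inhibitor. There, compound 2 gives 240 nM, which lies within the usual scatter of the value for compound 1. Compound 3 `CCOc1cc(-c2ccc3c(ccn3C)c2)cn2c(-c3cc(OC)c(OC)c(OC)c3)nnc12` has not yet been measured. It contains the same atoms as compound 2, joined differently: 1-methyl-1H-indol-5-yl in place of 1-methyl-1H-indol-6-yl on an aromatic carbon. Among the measured compounds shown here, only one measured step bears on this change: a 1.4-fold higher number from compound 1 to compound 2 (0.16 log units; within the scatter). That step exchanged 1H-indol-5-yl for 1-methyl-1H-indol-6-yl, and it stayed within the scatter. The group in compound 3, 1-methyl-1H-indol-5-yl, combines features of those two groups, so no step beyond the scatter is expected in this assay. With just two measured compounds, the range must stay wide. The expected change is a 1.4-fold lower number from compound 2 to compound 3 (0.15 log units; within the scatter). For compound 3 the estimated value is 170 nM, with an expected range of 50 nM to 450 nM.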

Compound 3, half-maximal inhibitory concentration: 210 nM
Estimate against measurement, compound 3: 1.2-fold (0.09 log units) below; low and high end bracket the measured number.
By their numbers in this assay, from the lowest: compounds 1, 3 and 2 (each within the scatter of the next).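

In this assay the change from 1-methyl-1H-indol-6-yl to 1-methyl-1H-indol-5-yl gives a 1.1-fold lower number from compound 2 to compound 3 (0.06 log units; within the scatter) and so shows that, with the same atoms, moving the attachment point between these two places has no effect that can be read. Among the compounds shown here, compound 3 also isolates the methyl for the first time: methyl in place of hydrogen on the aromatic nitrogen gives a 1.3-fold higher number from compound 1 to compound 3 (0.10 log units; within the scatter) and likewise stays too small to read, whereas the earlier step from compound 1 to compound 2 changed the methyl and the attachment point together. No measurement here gives a cause for how close these numbers lie.

On these data alone, it remains open whether an ethyl group or a longer chain on the indole nitrogen would also stay within the scatter. An amine or a carboxylic acid on the indole is equally untested among the compounds shown here.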